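Replacing Chloro with a Bromopentyl Ether

A few compounds are considered here, and "the series" means these few. Any claim that something is new, unique, unknown or untested is made for them only; others in the source may bear on it.

In a functional assay on A549 cells (Homo sapiens) for antiproliferative activity, read by MTT assay, with a stated time of 48 h (on this read-out lower numbers stand for stronger inhibition and higher numbers for weaker inhibition), compound 1 `COc1ccc(N(C)c2ccnc(Cl)n2)cc1Cl` gives 621 nM, within the scatter of compound 3 `COc1ccc(N(C)c2ccnc(Cl)n2)cc1O` at 381 nM, while compound 2 `COc1ccc(N(C)c2ccnc(Cl)n2)cc1[N+](=O)[O-]` gives 3780 nM. Compound 4 `COc1ccc(N(C)c2ccnc(Cl)n2)cc1OCCCCCBr` differs from compound 1 by (5-bromopentyl)oxy in place of chloro on an aromatic carbon. Two measured replacements of the same chloro bear on this change: nitro gives a 6.1-fold higher number from compound 1 to compound 2 (0.78 log units; beyond the scatter), and hydroxy gives a 1.6-fold lower number from compound 1 to compound 3 (0.21 log units; within the scatter). Neither replacement carries a chain, so the measured compounds offer only indirect guidance. The expected change is a small step to a higher number, a 2.4-fold higher number from compound 1 to compound 4 (0.38 log units; beyond the scatter). Compound 4 is estimated at 1500 nM, with an expected range of 400 nM to 5500 nM.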

Compound 4, half-maximal inhibitory concentration: 9720 nM
Estimate against measurement, compound 4: 6.5-fold (0.81 log units) below; measured number above the stated range.
By their numbers in this assay, from the lowest: compounds 3 and 1 (each within the scatter of the next); then compound 2; then compound 4.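

For the compounds shown here, at this position, ortho to a methoxy group, the (5-bromopentyl)oxy group gives the highest number so far in this assay, with a 16-fold higher number from compound 1 to compound 4 (1.19 log units; beyond the scatter) and, against the free hydroxy, a 26-fold higher number from compound 3 to compound 4 (1.41 log units; beyond the scatter). Even the nitro group, the weakest of the earlier replacements, stays lower (with a 2.6-fold higher number from compound 2 to compound 4 (0.41 log units; beyond the scatter)), so at this position a long chain on the oxygen counts against activity more than any small group shown. No measurement shown offers an explanation for this loss.

The compounds leave open whether the loss belongs to the length of the chain or to its terminal bromine. A plain pentyloxy group, a short ethoxy group or a chain ending in an amine would bear on that question.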